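Dichloro core variants: cytotoxicity on melanoma cells

A few compounds are considered here, and "the series" means these few. Any claim that something is new, unique, unknown or untested is made for them only; others in the source may bear on it.

Compound 1 `ClCc1ccc(Cn2cnc3c(Cl)ncnc32)cc1` carries the chloromethylbenzyl arm on one core; compound 2 `ClCc1ccccc1Cn1cnc2ncnc(Cl)c21` has the same atoms joined differently, and the difference between the two cores is not broken down here. In a functional assay on SK-MEL-5 cells (Homo sapiens) for cytotoxicity, read by sulforhodamine B assay, with a stated time of 48 h (a higher number here means that more compound is tolerated, a lower number that less compound is tolerated), compound 1 gives 74100 nM, while compound 2 gives 15800 nM, the lowest of the three numbers measured. Compound 3 `ClCc1ccc(Cn2cnc3c(Cl)nc(Cl)nc32)cc1` is compound 1 with chloro in place of hydrogen on an aromatic carbon; in this assay compound 3 gives 44700 nM, so that a 1.7-fold lower number from compound 1 to compound 3 (0.22 log units; within the scatter). Compound 4 `ClCc1ccccc1Cn1cnc2nc(Cl)nc(Cl)c21` applies the same change to compound 2, namely (chloro in place of hydrogen on an aromatic carbon). In this assay the step expected is a 1.6-fold lower number from compound 2 to compound 4 (0.20 log units; within the scatter), resting on the step of a 1.7-fold lower number from compound 1 to compound 3 (0.22 log units; within the scatter) made by the same change. Compound 4 is therefore expected near 10000 nM, within a range from 4000 nM to 30000 nM.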

Compound 4, concentration lethal to 50% of the cells: 5490 nM
Compound 4: middle estimate off by 1.8-fold (0.26 log units), on the high side; the measured number falls inside the stated range.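

In this assay, chloro in place of hydrogen on an aromatic carbon gives a 2.9-fold lower number from compound 2 to compound 4 (0.46 log units; beyond the scatter). The change carries from one core to the other with no difference in step size that can be told from the scatter: the same change on two cores in this assay, a 1.7-fold lower number (0.22 log units; within the scatter) from compound 1 to compound 3 and a 2.9-fold lower number (0.46 log units; beyond the scatter) from compound 2 to compound 4, 1.7-fold (0.24 log units) apart, within the scatter of two such steps. Within the data shown here, this rests on only two steps, one of them within the scatter on its own, so it shows agreement for these two cores and gives neither a rule for the series nor a cause.

Still open, as far as these compounds go, is whether an amine or a methoxy group at this place gives a comparable step. Also open, from the compounds shown here alone, is how the numbers respond when the chloromethyl group on the arm gives way to a hydroxymethyl group or a longer chain.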